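The source may hold more compounds than are shown below. What is called first, only, known or untested is meant among the compounds shown, and "the series" means these compounds.

Measured compounds in a functional assay on MCF7 cells (Homo sapiens) for antiproliferative activity, read by CellTiter-Glo, with a stated time of 5 days; a lower number here means a stronger inhibitor, a higher number a weaker inhibitor:
- compound 1 `CC/C(=C(/c1ccc(/C=C/C(=O)O)cc1)c1ccc2c(cnn2C)c1)c1ccc(F)cc1Cl` gives 81 nM
- compound 2 `CC/C(=C(/c1ccc(/C=C/C(=O)O)cc1)c1ccn2ccnc2c1)c1ccccc1` gives only a limit, > 500 nM
- compound 3 `CC/C(=C(/c1ccc(/C=C/C(=O)O)cc1)c1ccn2nncc2c1)c1ccccc1` gives only a limit, > 500 nM

Compound 2 stands at the limit of this assay, with no number behind it. Compound 3 sits at the same limit, so the step that the two limits leave unreadable from compound 2 to compound 3 cannot be read; this is the situation summed up in the limit of > 500 nM in this assay, at which 2 of the 3 values shown sit. Within the data shown here, compound 1 differs from compound 2 in two places at once, so no single step to it is known.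

The next compound, compound 4 `CC/C(=C(/c1ccc(/C=C/C(=O)O)cc1)c1ccc2scnc2c1)c1ccccc1`, changes compound 2 in one place: a group of 9 heavy atoms (7 carbon, 1 nitrogen, 1 sulfur; one five-membered aromatic ring with 2 hetero atoms, one six-membered aromatic ring of carbon only) in place of a group of 9 heavy atoms (7 carbon, 2 nitrogen; one five-membered aromatic ring with 2 hetero atoms, one six-membered aromatic ring with 1 hetero atom), on a double-bonded chain carbon bound to an aromatic carbon and a double-bonded chain carbon.

Among the measured compounds shown here, no measured step bears directly on this change. For the measured compounds named here, the two bicycles measured so far on this position both leave their compounds at the limit, and the only compound with a number, compound 1, also carries a different substituted phenyl on the chain. The expectation is therefore weakly founded: compound 4 is expected to be estimated at 300 nM, within 80 nM to 1500 nM, with a real chance that it too is reported only as a limit. The expected step from compound 2 to compound 4 is then an at least 1.6-fold lower number from compound 2 to compound 4 (0.22 log units; that floor lies within the scatter), though its size cannot be fixed from a limit.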

Compound 4, half-maximal inhibitory concentration: 90 nM
Compound 4: the middle estimate sits 3.3-fold (0.52 log units) above what was measured, and the stated range covers the measured number.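

In this assay, among these compounds, the 1,3-benzothiazol-5-yl group is the first at this position, on a double-bonded chain carbon bound to an aromatic carbon and a double-bonded chain carbon, to give a readable number while the rest of the molecule stays unchanged from compound 2: the result is an at least 5.5-fold lower number from compound 2 to compound 4 (0.74 log units; beyond the scatter), and likewise an at least 5.5-fold lower number from compound 3 to compound 4 (0.74 log units; beyond the scatter). The position therefore responds to the choice of bicycle, and two nine-atom groups can differ well beyond the scatter. The change alters two things at once, with a six-membered aromatic ring of carbon only and a sulfur in the five-membered ring, and these steps do not separate the two; compounds 2 and 3 each remain a limit rather than a number, so both steps are floors and the step between those two compounds cannot be read: the limit of > 500 nM in this assay, at which 2 of the 4 values shown sit.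

Still open, going by these compounds, is whether the sulfur or the carbon-only six-membered ring carries the gain, a question that a 1,3-benzoxazol-5-yl group at the same place would bear on directly. Also open, on these data alone, is how far the result holds with the chloro-fluoro-substituted phenyl of compound 1 on the chain, or with an amide in place of the carboxylic acid.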